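Carboxy to cyclopropylcarbamoyl: compound 2 to compound 3

The compounds below may be only part of what the source reports. "The series", "measured", "known", "first", "only" and "open" are said of these compounds alone.

In a functional assay on HL-60 cells (Homo sapiens) for antiproliferative activity (on this read-out lower numbers stand for stronger inhibition and higher numbers for weaker inhibition), compound 1 `CCOC(=O)c1ccc(Oc2ccc(OC)c(F)c2)cc1` gives 3500 nM. Compound 2 `COc1ccc(Oc2ccc(C(=O)O)cc2)cc1F` gives > 30000 nM, which is a limit and not a number. Its true position is therefore open, and it stands at the limit of > 30000 nM in this assay, at which 1 of the 2 values shown sits.

The next structure is compound 3 `COc1ccc(Oc2ccc(C(=O)NC3CC3)cc2)cc1F`. The change is cyclopropylamino in place of hydroxy on a carbonyl carbon, with cyclopropylamino in place of hydroxy on a carbonyl carbon.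

Within the data shown here, the one measured step bearing on this carbonyl is an at least 8.5-fold higher number from compound 1 to compound 2 (0.93 log units; beyond the scatter), where hydrogen takes the place of ethyl. That step lies beyond the scatter, and its size is only a minimum. Among the measured compounds shown here, no compound with cyclopropylamino on this carbonyl has been measured, so the evidence is indirect. Compound 3 loses the hydroxy of compound 2, so a return towards the level of compound 1 at 3500 nM is expected, though probably not all the way.

The expected step is an at least 4.2-fold lower number from compound 2 to compound 3 (0.63 log units; beyond the scatter), towards a lower number in this assay, and this size is loose since it starts from a limit. For compound 3 the estimated value is 7000 nM, with an expected range of 1800 nM to 28000 nM.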

Compound 3, half-maximal inhibitory concentration: 14100 nM
Estimate against measurement, compound 3: 2.0-fold (0.30 log units) below, within the range that was stated.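

In this assay, cyclopropylamino on the carbonyl carbon gives an at least 2.1-fold lower number from compound 2 to compound 3 (0.32 log units; beyond the scatter), the first measured sign that a group other than ethoxy at this place can also give a lower number than hydroxy does. Compound 2 is held only as a limit, so this step has a minimum size and no upper bound: the limit of > 30000 nM in this assay, at which 1 of the 3 values shown sits. Measured against ethoxy on the same carbonyl carbon, cyclopropylamino does not match it, with a 4.0-fold higher number from compound 1 to compound 3 (0.61 log units; beyond the scatter), which gives an order across these three compounds of ethoxy strongest, cyclopropylamino in the middle and hydroxy weakest.

The compounds shown leave open whether the cyclopropyl ring or the amide hydrogen carries the difference from hydroxy and from ethoxy, and plain amino, methylamino and dimethylamino on this carbonyl carbon would separate those two parts. Also open, going by these compounds, is whether a larger group here, such as cyclohexylamino or benzylamino, would move the number towards compound 1 or away from it.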